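The compounds below may be only part of what the source reports. "The series", "measured", "known", "first", "only" and "open" are said of these compounds alone.

Compound 1 `COc1ccc(-n2cc(NC(=O)c3cccc(NS(=O)(=O)c4ccccc4)c3)cn2)cc1` and compound 2 `COc1cccc(-n2cc(NC(=O)c3cccc(NS(=O)(=O)c4ccccc4)c3)cn2)c1` share one core. In a functional assay on HepG2 cells (Homo sapiens) for inhibition, read by MTT assay, with a stated time of 48 h (on this read-out higher numbers stand for weaker inhibition and lower numbers for stronger inhibition), compound 1 gives 35700 nM, and compound 2 gives 25000 nM. The change between them, (3-methoxyphenyl in place of 4-methoxyphenyl on an aromatic nitrogen), made a step of a 1.4-fold lower number from compound 1 to compound 2 (0.15 log units; within the scatter). Compound 3 `COc1ccc(-n2cc(NC(=O)c3ccc(NS(=O)(=O)c4ccccc4)cc3)cn2)cc1` is built on a different core; the difference between the two cores is not broken down here. In this assay compound 3 gives 57300 nM, the highest of the three numbers, within the scatter of compound 1 but beyond it from compound 2. Compound 4 `COc1cccc(-n2cc(NC(=O)c3ccc(NS(=O)(=O)c4ccccc4)cc3)cn2)c1` has not been measured and carries the same change relative to compound 3, (3-methoxyphenyl in place of 4-methoxyphenyl on an aromatic nitrogen), at the same place. Because the same change gave the step of a 1.4-fold lower number from compound 1 to compound 2 (0.15 log units; within the scatter), compound 4 is expected to take a step of a 1.4-fold lower number from compound 3 to compound 4 (0.15 log units; within the scatter). In this assay compound 4 is estimated at 41000 nM, between 20000 nM and 85000 nM.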

Compound 4, half-maximal inhibitory concentration: 64200 nM
Compound 4: the middle estimate sits 1.6-fold (0.19 log units) below what was measured; measured number inside the range.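

In this assay, putting 3-methoxyphenyl in place of 4-methoxyphenyl on the core of compound 3 gave a 1.1-fold higher number from compound 3 to compound 4 (0.05 log units; within the scatter). Set beside the earlier step, the change shows no measurable difference between the two cores: the same change on two cores in this assay, a 1.4-fold lower number (0.15 log units; within the scatter) from compound 1 to compound 2 and a 1.1-fold higher number (0.05 log units; within the scatter) from compound 3 to compound 4, 1.6-fold (0.20 log units) apart, within the scatter of two such steps This shows only that the change stays within the scatter on both cores; it does not show that the change has any real effect in either direction, or that it would behave the same way on a further core.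

All four compounds carry a methoxy group on that phenyl ring. As far as these compounds go, it remains open how an amine or a carboxylic acid in its place would read in this assay on either core.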